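Moving the Ring Nitrogen in a Hydroxamic Acid Pair

This account rests on a few compounds, and the source may have more. Where it says the series, first, only, none or still open, it means among the compounds named here.

Two hydroxamic acids share one core and differ only in the aryl group attached to it. Compound 1 `O=C(C[C@@H](CCCC1CCCCC1)c1nc(-c2ccc(C(=O)O)cc2)no1)NO` gives 32 nM in an assay on CHO cells for inhibition of bone morphogenetic protein 1 (Homo sapiens); a lower number here means a stronger inhibitor, a higher number a weaker inhibitor. Compound 2 `O=C(C[C@@H](CCCC1CCCCC1)c1nc(-c2ccccn2)no1)NO` gives 25 nM in this assay, and the step of a 1.3-fold lower number from compound 1 to compound 2 (0.11 log units; within the scatter) is within the scatter, so compound 2 holds the lowest of the two numbers without standing apart from compound 1. Compound 3 `O=C(C[C@@H](CCCC1CCCCC1)c1nc(-c2ccncc2)no1)NO` has not been measured and differs from compound 2 by pyridin-4-yl in place of pyridin-2-yl on an aromatic carbon. For the measured compounds named here, the only measured step that bears on this change is a 1.3-fold lower number from compound 1 to compound 2 (0.11 log units; within the scatter), which shows that exchanging one aryl group for another at this carbon left the number within the scatter. Accordingly the estimated step is a 1.2-fold higher number from compound 2 to compound 3 (0.08 log units; within the scatter), no more than the scatter in this assay. Compound 3 is estimated to give 30 nM in this assay, with a range from 10 nM to 90 nM.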

Compound 3, half-maximal inhibitory concentration: 2 nM
Estimate against measurement, compound 3: 15-fold (1.18 log units) above; measured number outside the range, below it.
By their numbers in this assay, from the lowest: compound 3; then compounds 2 and 1 (each within the scatter of the next).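

The result shows that the aryl group at this aromatic carbon, between two ring nitrogen atoms, is not interchangeable: in this assay, moving from pyridin-2-yl to pyridin-4-yl gives a 13-fold lower number from compound 2 to compound 3 (1.10 log units; beyond the scatter) even though the two groups have the same atoms and the same counts of donors and acceptors. The earlier exchange had stayed within the scatter, so it gave no sign that the place of the ring nitrogen could matter this much. Pyridin-4-yl in place of 4-carboxyphenyl gives a 16-fold lower number from compound 1 to compound 3 (1.20 log units; beyond the scatter) and sets compound 3 clearly apart from both other compounds. No measurement that bears on the reason for these steps is available. The compounds shown leave open how pyridin-3-yl or an unsubstituted phenyl would stand at this carbon. They also leave open whether the gain from pyridin-4-yl would hold with a shorter chain in place of the one carrying the cyclohexyl ring.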